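The source may hold more compounds than are shown below. What is called first, only, known or untested is meant among the compounds shown, and "the series" means these compounds.

Compound 3 `Cc1ccccc1NC(=S)N1CCc2c(sc(NC(=O)c3ccccc3Cl)c2C(N)=O)C1` gives 22600 nM in a functional assay on HL-60 cells (Homo sapiens) for antiproliferative activity, with a stated time of 24 h (a lower number here means a stronger inhibitor, a higher number a weaker inhibitor), the highest of the three numbers at hand. Compound 1 `NC(=O)c1c(NC(=O)c2ccccc2Cl)sc2c1CCN(C(=O)Nc1ccccc1Cl)C2` gives 12500 nM in this assay, and the step of a 1.8-fold higher number from compound 1 to compound 3 (0.26 log units; within the scatter) is small. Compound 2 `NC(=O)c1c(NC(=O)c2ccccc2Cl)sc2c1CCN(C(=S)Nc1ccccc1C(F)(F)F)C2` gives 10600 nM in this assay, and the step of a 2.1-fold higher number from compound 2 to compound 3 (0.33 log units; beyond the scatter) is modest.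

Compound 4 `Cc1ccccc1NC(=S)N1CCc2c(sc(NC(=O)c3ccccc3Br)c2C(N)=O)C1` differs from compound 3 by bromo in place of chloro on an aromatic carbon. Neither measured step touches this part of the molecule: the step from compound 1 to compound 3 exchanges the whole group on the ring nitrogen, and the step from compound 2 to compound 3 swaps a methyl for a trifluoromethyl on the other aromatic ring. The ring that carries the chloro stays the same in every measured compound, so the data give no direct guide. A single halogen exchange of this kind is expected to move the number little, with no step beyond the scatter in either direction, so a 1.1-fold lower number from compound 3 to compound 4 (0.05 log units; within the scatter) is the estimate. Compound 4 is therefore expected to give about 20000 nM in this assay, between 9000 nM and 45000 nM.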

Compound 4, half-maximal inhibitory concentration: > 50000 nM
Compound 4 gave a limit, no number; the forecaster's own chance of this, stated with the estimate: 15%; middle value at least 2.5-fold (0.39 log units) from the limit.
By their numbers in this assay, from the lowest: compounds 2, 1 and 3 (each within the scatter of the next, the first and the last beyond it). At a limit, above all of these: compound 4.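

Going by these compounds alone, the halogen on this ring was the same in compound 1, compound 2 and compound 3, so this is the first reading of the position, and the exchange of chloro for bromo gives an at least 2.2-fold higher number from compound 3 to compound 4 (0.34 log units; beyond the scatter). This change puts one heavy atom in place of one heavy atom, with no hydrogen-bond donor or acceptor on either side, yet it lies beyond the scatter, whereas exchanging the whole group on the ring nitrogen gave a 1.8-fold higher number from compound 1 to compound 3 (0.26 log units; within the scatter). Compound 4 gives a limit and no number, so the full size of its step stays unknown: the limit of > 50000 nM in this assay, at which 1 of the 4 values shown sits.

Going by these compounds, how a fluoro or a methoxy group in this place would read stays open. Also open, on these data alone, is whether bromo would have the same effect alongside the trifluoromethyl of compound 2.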